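A few compounds are considered here, and "the series" means these few. Any claim that something is new, unique, unknown or untested is made for them only; others in the source may bear on it.

Compound 2 `CN1C[C@@H](c2ccccc2)[C@@]2(Cc3ccccc3C2=O)[C@@]12C(=O)Nc1ccccc12` stands highest of the two numbers in a functional assay on the whole organism (strain Wister albino) for inhibition, with Rattus norvegicus as the target, read by paw edema, with stated times of 1 h and 3 h, at a dose of 50 mg/kg by the intraperitoneal route (a higher number here means more inhibition at the dose given (going by the name of the read-out), a lower number less inhibition), where compound 2 gives 42.5%. Compound 1 `Cc1ccc([C@@H]2CN(C)[C@]3(C(=O)Nc4ccccc43)[C@]23Cc2ccccc2C3=O)cc1` gives 27.4% in this assay, and the step of a number 15.1 percentage points higher from compound 1 to compound 2 (beyond the scatter) arose from hydrogen in place of methyl on an aromatic carbon. Compound 3 `CN1C[C@@H](c2ccc(F)cc2)[C@@]2(Cc3ccccc3C2=O)[C@@]12C(=O)Nc1ccccc12` differs from compound 2 by fluoro in place of hydrogen on an aromatic carbon. Within the data shown here, no measured step adds a fluoro; the only step available, a number 15.1 percentage points higher from compound 1 to compound 2 (beyond the scatter), concerns a methyl on an aromatic carbon and suggests that a group entering there can lower the number. A modest decrease is therefore expected, a number 6.5 percentage points lower from compound 2 to compound 3 (within the scatter). Compound 3 is estimated at 36% in this assay, within 22% to 50%.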

Compound 3, a percentage reported as inhibition, in the whole organism at one dose (the size of the read-out at that dose, not a potency): 21.1%
For compound 3 the middle estimate is 14.9 percentage points above the measured one, and the stated range ends above it.
By their numbers in this assay, from the lowest: compounds 3 and 1 (each within the scatter of the next); then compound 2.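

In this assay the change from phenyl to 4-fluorophenyl gives a number 21.4 percentage points lower from compound 2 to compound 3 (beyond the scatter) and shows that the lower number at this place, para to a large group, does not belong to methyl alone. Fluoro set against methyl gives a number 6.3 percentage points lower from compound 1 to compound 3 (within the scatter) and so cannot be told apart from it here, while hydrogen stands clear of both. Nothing available here explains the drop. On these data alone, whether a larger halogen such as chlorine, or an amine or a methoxy group, at this place would also go with a lower number remains open.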